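The source may report more compounds than this note shows. Statements on the series, on what has been measured and on what is new or still open speak of the compounds shown alone.

Measured so far in a functional assay on Jurkat cells (Homo sapiens) for inhibition; on this read-out higher numbers stand for weaker inhibition and lower numbers for stronger inhibition:
Compound 1, `CC(C)[C@H](NC(=O)COc1cccc2ccccc12)C(=O)N[C@@H](CC(=O)O)C(=O)CSc1nc(-c2ccccc2)cs1`, gives > 200000 nM, which is a limit of the assay.
Compound 2, `CC(C)[C@H](NC(=O)COc1cccc2ccccc12)C(=O)N[C@@H](CC(=O)O)C(=O)CSc1nccc(C(F)(F)F)n1`, gives > 200000 nM, which is also a limit of the assay.

Compound 2 therefore stands only at a limit, and the step that the two limits leave unreadable from compound 1 to compound 2 cannot be read, since both values sit at the limit of > 200000 nM in this assay, at which 2 of the 2 values shown sit. Compound 3, `CC(C)[C@H](NC(=O)COc1cccc2ccccc12)C(=O)N[C@@H](CC(=O)O)C(=O)COc1nncc(Cl)c1Cl`, differs from compound 2 by (4,5-dichloropyridazin-3-yl)oxy in place of (4-(trifluoromethyl)pyrimidin-2-yl)sulfanyl on a saturated chain carbon bound to a carbonyl carbon. No readable measured step bears on this change, so the numbers give no direction for it. The step from compound 2 to compound 3 is expected, loosely, to be an at least 6.6-fold lower number from compound 2 to compound 3 (0.82 log units; beyond the scatter). Compound 3 is estimated at 30000 nM, within a range of 1000 nM to 200000 nM.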

Compound 3, half-maximal inhibitory concentration: > 200000 nM
Compound 3: a limit, no number; the forecaster's own chance of this, stated with the estimate: 50%; middle value at least 6.6-fold (0.82 log units) away from the limit.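

Compound 3 also gives a limit of the assay, not a number, and its steps from compound 1 and compound 2 cannot be read: the limit of > 200000 nM in this assay, at which 3 of the 3 values shown sit.

On these data alone, whether swapping these groups on the shared core changes inhibition at all stays open.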